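Compound 3 to Compound 4: Azepanyl Replaces Furanyl

A few compounds are considered here, and "the series" means these few. Any claim that something is new, unique, unknown or untested is made for them only; others in the source may bear on it.

Compound 1, `O=C(O)c1cccc(Cc2c(-c3ccccc3)nn3ccccc23)n1`, gives 2300 nM in a functional assay on cells for antagonist activity at prostaglandin E2 receptor EP1 subtype (Rattus norvegicus), read by fluorescence and calcium flux, with a stated time of 60 s; on this read-out lower numbers stand for stronger inhibition and higher numbers for weaker inhibition.
Compound 2, `CS(=O)(=O)c1ccc2c(Cc3cccc(C(=O)O)n3)c(-c3ccccc3)nn2c1`, gives 5400 nM in this assay.
Compound 3, `O=C(O)c1cccc(Cc2c(-c3ccco3)nn3cc(Cl)ccc23)n1`, gives 1200 nM in this assay.

Among the three measured compounds, compound 3 has the lowest number in this assay, though its gap to compound 1 lies within the scatter; only its gap to compound 2 is beyond it. Compound 4, `O=C(O)c1cccc(Cc2c(N3CCCCCC3)nn3cc(Cl)ccc23)n1`, differs from compound 3 in one place: azepan-1-yl in place of furan-2-yl on an aromatic carbon. Among the measured compounds shown here, the only measured step, a 2.3-fold higher number from compound 1 to compound 2 (0.37 log units; beyond the scatter), concerns a different change on the fused core and does not bear on swapping an aromatic five-membered ring for a saturated seven-membered amine. For the measured compounds named here, no measured step therefore informs this change directly, and the expectation must stay wide. Compound 4 is expected to land near compound 3 or somewhat weaker, with the estimated step being a 2.1-fold higher number from compound 3 to compound 4 (0.32 log units; beyond the scatter). Compound 4 is estimated at 2500 nM in this assay, within a range from 600 nM to 10000 nM.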

Compound 4, half-maximal inhibitory concentration: 1400 nM
Estimate against measurement, compound 4: 1.8-fold (0.25 log units) above; the measured number falls inside the stated range.
By their numbers in this assay, from the lowest: compounds 3, 4 and 1 (each within the scatter of the next); then compound 2.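

Among the compounds shown here, on the aromatic carbon next to the ring nitrogen, the earlier compounds carried only aromatic rings, and azepan-1-yl in place of furan-2-yl gives a 1.2-fold higher number from compound 3 to compound 4 (0.07 log units; within the scatter) in this assay. In this pair, therefore, a seven-membered non-aromatic ring reads the same as a five-membered aromatic ring, so an aromatic ring at this place is not needed for a value in this range. Nothing measured here explains why the two groups read alike.
From the compounds shown here alone, whether a smaller cyclic amine such as piperidine or pyrrolidine, or an open-chain amine such as diethylamine, would read alike at this place remains open. Going by these compounds, it is also open whether azepan-1-yl would give the same reading on a core with methylsulfonyl instead of chlorine.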